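Ring-bearing esters on a shared quinone core: cytotoxicity notes

A few compounds are considered here, and "the series" means these few. Any claim that something is new, unique, unknown or untested is made for them only; others in the source may bear on it.

Measured compounds:
compound 1 `CC(C)=CC[C@@H](OC(=O)CC(C)(O)c1ccccc1)C1=CC(=O)c2c(O)ccc(O)c2C1=O` — in a functional assay on DU-145 cells (Homo sapiens) for cytotoxicity, read by MTT assay (on this read-out higher numbers stand for weaker inhibition and lower numbers for stronger inhibition), compound 1 gives only a limit, > 100000 nM.
compound 2 `CC(C)=CC[C@@H](OC(=O)C1CCCCO1)C1=CC(=O)c2c(O)ccc(O)c2C1=O` — compound 2 gives 24700 nM.
compound 3 `CC(C)=CC[C@@H](OC(=O)CCO)C1=CC(=O)c2c(O)ccc(O)c2C1=O` — compound 3 gives 55300 nM.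

Among the two real numbers compound 3 stands highest; its nearest neighbour is compound 2, with a 2.2-fold higher number from compound 2 to compound 3 (0.35 log units; beyond the scatter). The value of compound 1 is a limit of this assay and carries no number, as noted in the limit of > 100000 nM in this assay, at which 1 of the 3 values shown sits.

The next compound is compound 4 `CC(C)=CC[C@@H](OC(=O)C1CCCOC1)C1=CC(=O)c2c(O)ccc(O)c2C1=O`. Relative to compound 3 the change is oxan-3-yl in place of 2-hydroxyethyl on a carbonyl carbon. Among the compounds with values here, the one measured step that bears on it runs the other way: the oxan-2-yl ester of compound 2 gave a modestly lower number than the 2-hydroxyethyl ester of compound 3, as a 2.2-fold higher number from compound 2 to compound 3 (0.35 log units; beyond the scatter) shows. Oxan-3-yl is a ring of the same size and hetero atom, so a step of similar size back toward lower numbers is expected in this assay, though not beyond a modest one.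

Compound 4 is therefore estimated at 25000 nM, with a range from 10000 nM to 60000 nM. The expected step is a 2.2-fold lower number from compound 3 to compound 4 (0.34 log units; beyond the scatter).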

Compound 4, half-maximal inhibitory concentration: 29700 nM
For compound 4 the middle estimate is 1.2-fold (0.07 log units) below the measured one, and the stated range covers the measured number.
By their numbers in this assay, from the lowest: compounds 2, 4 and 3 (each within the scatter of the next, the first and the last beyond it). At a limit, above all of these: compound 1.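

In this assay the oxan-3-yl ester of compound 4 and the oxan-2-yl ester of compound 2 do not separate, with a 1.2-fold higher number from compound 2 to compound 4 (0.08 log units; within the scatter), so on this carbonyl carbon the two ring attachments cannot be told apart. The ring and the open chain also come closer than before: where compound 2 stood beyond the scatter of the 2-hydroxyethyl ester, this ring stays within it, with a 1.9-fold lower number from compound 3 to compound 4 (0.27 log units; within the scatter). Compound 1 carries a limit and no number, so an at least 3.3-fold lower number from compound 1 to compound 4 (0.52 log units; beyond the scatter) gives only a floor: the limit of > 100000 nM in this assay, at which 1 of the 4 values shown sits.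

Still open, on these data alone, is how an oxan-4-yl ester, a cyclohexyl ester or a piperidin-3-yl ester, with an amine in the ring, would read on this carbonyl carbon. As far as these compounds go, a carboxylic acid on a longer chain in place of 2-hydroxyethyl is equally open.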